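The source may report more compounds than this note shows. Statements on the series, on what has been measured and on what is new or still open speak of the compounds shown alone.

Measured so far:
compound 1, `O=C1NC(=O)C(Cc2ccc(Oc3ccc(Cl)cc3Cl)cc2)S1`, 101 nM
compound 2, `O=C1NC(=O)C(Cc2ccc(Oc3ccc(Cl)cc3)cc2)S1`, 240 nM

In a functional assay for agonist activity at Free fatty acid receptor 1 (Homo sapiens), read by FLIPR, in the presence of a further agent that is not named here (a higher number here means that more compound is needed for the effect, a lower number that less compound is needed), compound 1 has the lower of the two numbers, and compound 2 lies a 2.4-fold higher number from compound 1 to compound 2 (0.38 log units; beyond the scatter) away from it. Compound 3, `O=C1NC(=O)C(Cc2ccc(Oc3ccc(C(F)(F)F)cc3Cl)cc2)S1`, has not been measured. It differs from compound 1 in one place: trifluoromethyl in place of chloro on an aromatic carbon. Going by the values given here, the only measured step, a 2.4-fold higher number from compound 1 to compound 2 (0.38 log units; beyond the scatter), concerns the other chloro group, the one that is kept in compound 3, so no measured step bears directly on the change to compound 3; the data show only that a single change on this ring of compound 1 moved the number by a modest amount. Compound 3 is therefore expected to show a step of a 1.1-fold lower number from compound 1 to compound 3 (0.05 log units; within the scatter), a change estimated to remain within the scatter. Compound 3 is estimated at 90 nM, with a range from 35 nM to 250 nM.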

Compound 3, half-maximal effective concentration: 78 nM
For compound 3 the middle estimate is 1.2-fold (0.06 log units) above the measured one; low and high end bracket the measured number.
By their numbers in this assay, from the lowest: compounds 3 and 1 (each within the scatter of the next); then compound 2.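

In this assay the exchange of chloro for trifluoromethyl gives a 1.3-fold lower number from compound 1 to compound 3 (0.11 log units; within the scatter) and so makes no change beyond the scatter, although the entering group has 4 heavy atoms where the leaving one has 1. Going by these compounds alone, the earlier pair spoke only of the other chloro group, so this is the first reading at the place para to a large group, and it shows that this place accepts trifluoromethyl as well as chloro. No measurement accompanies the result that would say why the two groups read alike.

On these data alone, what a hydrogen, a nitrile, an amine or a carboxylic acid would do at this place stays open. As far as these compounds go, it also stays open whether the chloro group that is kept in compound 3 matters as much there as its loss from compound 1 suggests.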